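Fluorines on the N-phenyl of a triazole carboxamide

This account rests on a few compounds, and the source may have more. Where it says the series, first, only, none or still open, it means among the compounds named here.

Compound 1 `Cc1c(C(=O)Nc2ccc(Oc3ccnc4[nH]ccc34)c(F)c2)nnn1-c1ccc(F)c(F)c1`: 570 nM
Compound 2 `O=C(Nc1ccc(Oc2ccnc3[nH]ccc23)c(F)c1)c1nnn(-c2ccccc2)c1C(F)(F)F`: 220 nM

The study measured two compounds in a functional assay on A549 cells (Homo sapiens) for cytotoxicity, read by MTT assay, with a stated time of 72 h; on this read-out higher numbers stand for weaker inhibition and lower numbers for stronger inhibition. Compound 1 gives 570 nM in this assay, and compound 2 gives 220 nM. Among the compounds with values here, compound 2 therefore holds the lower of the two numbers, and the gap to compound 1 lies beyond the scatter of repeated measurements; the two structures differ in more than one place, so no single-point step connects them.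

The step followed here leads from compound 2 to compound 3 `O=C(Nc1ccc(Oc2ccnc3[nH]ccc23)c(F)c1)c1nnn(-c2ccc(F)c(F)c2)c1C(F)(F)F`. The change is 3,4-difluorophenyl in place of phenyl on an aromatic nitrogen. Within the data shown here, no step between measured compounds reports how this change alone acts in this assay, and compound 1, which also carries the 3,4-difluorophenyl, differs from compound 2 in a second place as well.

Among the measured compounds shown here, with no direct precedent, a step of no size beyond the scatter in this assay is expected, and a 1.1-fold higher number from compound 2 to compound 3 (0.06 log units; within the scatter) expresses that. Compound 3 is estimated at 250 nM, with a range from 100 nM to 700 nM.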

Compound 3, half-maximal inhibitory concentration: 350 nM
The estimate for compound 3 lay 1.4-fold (0.15 log units) below the measured number; measured number inside the range.
By their numbers in this assay, from the lowest: compounds 2, 3 and 1 (each within the scatter of the next, the first and the last beyond it).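

In this assay, the 3,4-difluorophenyl in place of phenyl on the aromatic nitrogen can now be read alone, with the trifluoromethyl group held fixed, and it comes with a step that stays within the scatter (a 1.6-fold higher number from compound 2 to compound 3 (0.20 log units; within the scatter)). Compound 3 also joins compound 1 to this pair: with the 3,4-difluorophenyl held fixed, trifluoromethyl in place of methyl on the aromatic carbon comes with a step that likewise stays within the scatter (a 1.6-fold lower number from compound 1 to compound 3 (0.21 log units; within the scatter)). The gap between compound 1 and compound 2, which lies beyond the scatter, thus divides into two single changes, neither of which exceeds the scatter by itself, and no measurement shown here explains these numbers.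

The compounds shown leave open how this position responds to groups other than phenyl and 3,4-difluorophenyl on the aromatic nitrogen, such as a pyridine ring, a phenyl bearing an amine or a carboxylic acid, or a longer alkyl chain. They also leave open whether the aromatic carbon that carries methyl or trifluoromethyl would accept a nitrile or an amine.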